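Working notes on the amide acid series, outlook for compound 3

This account rests on a few compounds, and the source may have more. Where it says the series, first, only, none or still open, it means among the compounds named here.

Measured so far:
compound 1: `O=C(O)COc1cccc(NC(=O)c2ccc(Oc3ccccc3)cc2)c1` — > 10000 nM
compound 2: `CCCCOc1ccc(C(=O)Nc2cccc(C(=O)O)c2)cc1` — 105 nM

Of the compounds shown here, two have been measured in an assay on isolated protein for agonist activity at Bile acid receptor (Homo sapiens), read by TR-FRET, with a stated time of 3 h, in the absence of a further agent; a lower number here means that less compound is needed, a higher number that more compound is needed for the effect. For compound 1 the result is a limit of the assay, > 10000 nM, and not a number. That result sits at the limit of > 10000 nM in this assay, at which 1 of the 2 values shown sits. Among the compounds with values here, compound 2 gives 105 nM in this assay, the only numerical value so far, so compound 2 stands as the single measured reference point of the series, and nothing can yet be said about how wide the series spreads.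

Compound 3, `O=C(O)c1cccc(NC(=O)c2ccc(OCc3ccccc3)cc2)c1`, is not yet measured in this assay. It differs from compound 2 in one place: phenyl in place of propyl on a saturated chain carbon bound to an oxygen on an aromatic ring, so that the butoxy of compound 2 becomes a benzyloxy. Within the data shown here, no step between two measured compounds covers this change, so there is no measured precedent for it here. The step expected is a 1.3-fold lower number from compound 2 to compound 3 (0.12 log units; within the scatter), small, probably within the usual scatter, and of uncertain direction. Compound 3 is estimated at 80 nM in this assay, with a range from 25 nM to 300 nM.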

Compound 3, half-maximal effective concentration: 135 nM
The estimate for compound 3 lay 1.7-fold (0.23 log units) below the measured number; low and high end bracket the measured number.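

In this assay, the first step read at this position, on a saturated chain carbon bound to an oxygen on an aromatic ring, is a 1.3-fold higher number from compound 2 to compound 3 (0.11 log units; within the scatter), with phenyl in place of propyl. The change from butoxy to benzyloxy brings in a six-membered aromatic ring of carbon only, yet the two compounds cannot be told apart in this assay, so this position accepts an aromatic ring as well as a plain chain, at least for this one pair on this core. The data shown hold no measured property that would give a reason for this result.

As far as these compounds go, whether the same holds for a longer chain such as hexyl, for an amine on the chain, or for a phenyl carrying a fluorine or a methoxy group remains open, as a single step cannot show how far this position goes. Compound 1 gives > 10000 nM, a limit of the assay and not a number, and it differs from the other two compounds in more than one place, so the change behind that limit remains unassigned.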